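Fluoro to Bromo on the Aryl Ring: A Small Step

This account rests on a few compounds, and the source may have more. Where it says the series, first, only, none or still open, it means among the compounds named here.

Measured in a functional assay on NCI-H727 cells (Homo sapiens), read by fluorescence and BrdU incorporation, with a stated time of 48 h, tested at 10 uM; on this read-out lower numbers stand for a stronger effect and higher numbers for a weaker effect at the one concentration tested:
compound 1, `COc1cc(OC)c(C(=O)/C=C/c2ccccc2)c(OC)c1`, gives 34%
compound 2, `COc1cc(OC)c(C(=O)/C=C/c2ccc(Cl)cc2)c(OC)c1`, gives 40%
compound 3, `COc1cc(OC)c(C(=O)/C=C/c2ccc(F)cc2)c(OC)c1`, gives 31%

Compound 3 stands lowest of the three numbers shown, but only by steps that stay within the scatter: a number 3 percentage points lower from compound 1 to compound 3 (within the scatter) and a number 9 percentage points lower from compound 2 to compound 3 (within the scatter). Within the data shown here, no compound in this set is set apart from the others beyond the scatter.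

Compound 4, `COc1cc(OC)c(C(=O)/C=C/c2ccc(Br)cc2)c(OC)c1`, has not yet been measured. Its difference from compound 3 is bromo in place of fluoro on an aromatic carbon.

Among the measured compounds shown here, the steps that bear on this change are the halogen exchanges already seen: a number 6 percentage points higher from compound 1 to compound 2 (within the scatter) and a number 9 percentage points lower from compound 2 to compound 3 (within the scatter), both within the scatter. Nothing among the three measured compounds shows a halogen on that aromatic carbon moving the read-out beyond the scatter. For compound 4 the expected step is therefore a number 7 percentage points higher from compound 3 to compound 4 (within the scatter) in this assay, that is, none beyond the scatter. Compound 4 is estimated at 38%, with a range from 26% to 50%.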

Compound 4, a percentage reported as activity, at one concentration (the size of the read-out at that concentration, not a potency): 39%
Compound 4: the middle estimate sits 1 percentage points below what was measured, within the range that was stated.
By their numbers in this assay, from the lowest: compounds 3, 1, 4 and 2 (each within the scatter of the next).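

Against fluoro the bromo group gives a number 8 percentage points higher from compound 3 to compound 4 (within the scatter) and against chloro it gives a number 1 percentage points lower from compound 2 to compound 4 (within the scatter) while against hydrogen it gives a number 5 percentage points higher from compound 1 to compound 4 (within the scatter) in this assay and so adds a third halogen to the comparison at this place. On this aromatic carbon, para to a large group, hydrogen and all three halogens shown now lie within the scatter of one another, so no exchange among them separates any two compounds in this set. No measurement here offers an explanation for these small steps or for the lack of any larger one.

The compounds shown leave open whether an amine or a carboxylic acid on this carbon would move the read-out beyond the scatter. They also leave open whether a halogen at another place on the ring would do so.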